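Cyclopropyl amide in place of the hydroxyphenyl anilide

This account rests on a few compounds, and the source may have more. Where it says the series, first, only, none or still open, it means among the compounds named here.

Compound 1 `O=C(Nc1ccccc1O)c1cccc(N2C(=O)c3ccccc3C2=O)c1` gives 77 nM in an in vitro functional assay on HEK293-A cells for antagonist activity at metabotropic glutamate receptor 5 (Rattus norvegicus), read by calcium flux (a lower number here means a stronger inhibitor, a higher number a weaker inhibitor), the lowest of the two numbers reported in the series. Compound 3 `O=C(Nc1cccc(NC(=O)C2CCC2)c1)c1cccc(Cl)c1` gives 5270 nM in this assay, a gap from compound 1 that lies beyond the scatter. Compound 2 `COc1ccccc1C(=O)Nc1cccc(NC(=O)c2ccc(Cl)c(Cl)c2)c1` is reported only as a limit of this assay, > 30000 nM, and not as a number (the limit of > 30000 nM in this assay, at which 1 of the 3 values shown sits). Among the compounds with values here, no step between measured compounds is recorded. Compound 4 `O=C(NC1CC1)c1cccc(N2C(=O)c3ccccc3C2=O)c1` carries cyclopropyl in place of 2-hydroxyphenyl on an amide-type nitrogen; the hydroxyl donor and acceptor of the hydroxyphenyl leave with it, and nothing in the measured set tests that change. The step from compound 1 to compound 4 is expected to be a loss, a 39-fold higher number from compound 1 to compound 4 (1.59 log units; beyond the scatter) in this assay, beyond the scatter. Compound 4 is expected to give 3000 nM, within 400 nM to 25000 nM.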

Compound 4, half-maximal inhibitory concentration: > 30000 nM
Compound 4 ended at the assay's limit; the forecaster's own chance of this, stated with the estimate: 25%; middle value at least 10-fold (1.00 log units) from the limit.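

Within the data shown here, this is the first single-change comparison: cyclopropyl in place of 2-hydroxyphenyl on the amide-type nitrogen, with the core of compound 1 kept, gives an at least 380-fold higher number from compound 1 to compound 4 (2.59 log units; beyond the scatter) in this assay. The core does not hold its activity in this assay without the 2-hydroxyphenyl group, so this position tolerates at least this change poorly. On these data alone, the reading for compound 4 is a limit, not a number, and the true size of the loss stays unknown: the limit of > 30000 nM in this assay, at which 2 of the 4 values shown sit.

As far as these compounds go, whether the loss tracks the hydroxyl or the aromatic ring stays open. An unsubstituted phenyl on this nitrogen would separate the two.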